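The source may report more compounds than this note shows. Statements on the series, on what has been measured and on what is new or still open speak of the compounds shown alone.

Measured so far:
compound 1 `NC(=O)c1ncn2c(=O)n(Cc3ccccc3)nnc12` — > 50000 nM
compound 2 `NC(=O)c1ncn2c(=O)n(Cc3ccco3)nnc12` — > 50000 nM
compound 3 `NC(=O)c1nc[nH]c1N/N=N/Cc1ccccc1` — > 50000 nM

In a functional assay on U-373MG ATCC cells for inhibition, with U373 MG (Homo sapiens) as the target, read by MTT assay, with a stated time of 7 days (on this read-out higher numbers stand for weaker inhibition of growth and lower numbers for stronger inhibition of growth), compound 1 gives only a limit, > 50000 nM. Compound 2 likewise gives only a limit in this assay, > 50000 nM. The step that the two limits leave unreadable from compound 1 to compound 2 is therefore unreadable; the change is furan-2-yl in place of phenyl on a saturated chain carbon bound to an aromatic nitrogen. Compound 3 also returns only a limit in this assay, > 50000 nM. Compound 3 carries a different core from compound 1; that difference is not broken down here. All three values sit at the limit of > 50000 nM in this assay, at which 3 of the 3 values shown sit.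

Compound 4 `NC(=O)c1nc[nH]c1N/N=N/Cc1ccco1` is not yet measured. It stands to compound 3 as compound 2 stands to compound 1, by furan-2-yl in place of phenyl on a saturated chain carbon bound to a double-bonded nitrogen; the place differs, being a saturated chain carbon bound to a double-bonded nitrogen rather than one bound to an aromatic nitrogen, so this is the same kind of change, not the same change. Because a step that the two limits leave unreadable from compound 1 to compound 2 could not be read, and because compound 3 sits at the limit of > 50000 nM in this assay, at which 3 of the 3 values shown sit, compound 4 is expected to remain at the limit, a step that the limit leaves unreadable from compound 3 to compound 4. The estimate for compound 4 in this assay is 80000 nM, with an expected range from 30000 nM to 300000 nM.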

Compound 4, concentration for 50% growth inhibition: > 50000 nM
Compound 4: a limit, no number (the forecaster's own chance of this, stated with the estimate: 90%); the middle value does not contradict the limit.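

For the compounds shown here, compound 3 and compound 4 each return only a limit in this assay, so no step between them can be read. The compounds shown leave open whether furan-2-yl in place of phenyl changes growth inhibition at all on either core.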